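Swapping fluoro for chloro in compound 1

A few compounds are considered here, and "the series" means these few. Any claim that something is new, unique, unknown or untested is made for them only; others in the source may bear on it.

Compound 1 `CN(C)c1ccc(/C=C/c2c(F)cccc2Cl)cc1` gives 19.2 nM in a functional assay on LS174T cells (Homo sapiens) for antiproliferative activity; a higher number here means a weaker inhibitor, a lower number a stronger inhibitor
Compound 2 `CNc1ccc(/C=C/c2c(F)cccc2Cl)cc1` gives 7.6 nM in this assay

Compound 1 holds the higher of these two numbers. Compound 3 `CN(C)c1ccc(/C=C/c2c(Cl)cccc2Cl)cc1` keeps the core of compound 1 with one change, (chloro in place of fluoro on an aromatic carbon), chloro in place of fluoro on an aromatic carbon. Within the data shown here, the only measured step, a 2.5-fold lower number from compound 1 to compound 2 (0.40 log units; beyond the scatter), is modest and lies on the nitrogen, so it bears only loosely on this change. Among the measured compounds shown here, no measured step touches the fluoro group, so no shift beyond the scatter is expected in this assay here. The expected step is a 1.1-fold higher number from compound 1 to compound 3 (0.06 log units; within the scatter) as a rough estimate. For compound 3 the estimated value is 22 nM, with an expected range of 8 nM to 55 nM overall.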

Compound 3, half-maximal inhibitory concentration: 214 nM
Compound 3: middle estimate off by 9.7-fold (0.99 log units), on the low side, and the stated range ends below it.
By their numbers in this assay, from the lowest: compound 2; then compound 1; then compound 3.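

In this assay chloro in place of fluoro on an aromatic carbon, ortho to a large group, gives an 11-fold higher number from compound 1 to compound 3 (1.05 log units; beyond the scatter) and so makes a far weaker inhibitor. This position is therefore sensitive to a change of a single heavy atom, and the step is large where the step on the nitrogen, a 2.5-fold lower number from compound 1 to compound 2 (0.40 log units; beyond the scatter), is modest. Nothing available accounts for the loss.

Going by these compounds, whether hydrogen, methyl or methoxy at this place would stay close to fluoro remains open. So does whether the same exchange costs as much with the single methyl on the nitrogen of compound 2.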